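The compounds below may be only part of what the source reports. "The series", "measured", "known", "first", "only" and "open" are said of these compounds alone.

Working notes on the series in an ADME assay on Vero 76 cells (Chlorocebus sabaeus) for cytotoxicity, read by MTT assay, with a stated time of 96 h; on this read-out lower numbers stand for higher toxicity in this test and higher numbers for lower toxicity in this test. Compound 1 (`NS(=O)(=O)c1ccc(N2N=C(c3ccccc3)CC2c2ccccc2F)cc1`) gives 28000 nM and compound 3 (`NS(=O)(=O)c1ccc(N2N=C(c3ccccc3)CC2c2ccccc2Cl)cc1`) gives 26000 nM. Compound 2 (`Cc1ccccc1C1CC(c2ccc(OCc3ccccc3)cc2)=NN1c1ccc(S(N)(=O)=O)cc1`) gives 100000 nM, the highest of the three numbers and beyond the scatter from both others. Compound 4 (`NS(=O)(=O)c1ccc(N2N=C(c3ccc(OCc4ccccc4)cc3)CC2c2ccc(F)cc2)cc1`) is not yet measured. It carries 4-fluorophenyl in place of 2-methylphenyl on a saturated ring carbon. For the measured compounds named here, the only measured step, a 1.1-fold lower number from compound 1 to compound 3 (0.03 log units; within the scatter), lies within the scatter, but it is chloro in place of fluoro on an aromatic carbon, so it bears only loosely on this change. No step beyond the scatter is therefore expected in this assay, and the estimated step is a 1.4-fold lower number from compound 2 to compound 4 (0.15 log units; within the scatter). Compound 4 is expected at 70000 nM, within an estimated range of 30000 nM to 100000 nM.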

Compound 4, half-maximal cytotoxic concentration: 90000 nM
Compound 4: middle estimate off by 1.3-fold (0.11 log units), on the low side, within the range that was stated.
By their numbers in this assay, from the lowest: compounds 3 and 1 (each within the scatter of the next); then compounds 4 and 2 (each within the scatter of the next).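

In this assay, the saturated ring carbon accepts 4-fluorophenyl in place of 2-methylphenyl with a 1.1-fold lower number from compound 2 to compound 4 (0.05 log units; within the scatter), the first step read at this position on the core of compound 2. Methyl and its ring place were exchanged for fluorine and another ring place together, so the step cannot assign anything to either alone. No measured evidence explains the result.

Still open, going by these compounds, is whether a non-aromatic group at this carbon, such as cyclohexyl, or a phenyl carrying a carboxylic acid or an amine, would give a step beyond the scatter.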